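Acetyl in Place of Trifluoromethoxy in an Antiproliferative Series

This account rests on a few compounds, and the source may have more. Where it says the series, first, only, none or still open, it means among the compounds named here.

Of the compounds shown here, two sharing one core have been measured so far in a functional assay on SK-OV-3 cells (Homo sapiens) for antiproliferative activity, read by MTT assay, with a stated time of 72 h; on this read-out lower numbers stand for stronger inhibition and higher numbers for weaker inhibition. There compound 1 (`O=C(CCc1cccc2c1B(O)OC2)Nc1cccc(-c2ccccc2)c1`) gives 250 nM, and compound 2 (`O=C(CCc1cccc2c1B(O)OC2)Nc1cccc(-c2cccc(OC(F)(F)F)c2)c1`) gives 460 nM. On these numbers compound 2 stands level with compound 1, since the two values lie within the scatter of each other.

Compound 3 (`CC(=O)c1cccc(-c2cccc(NC(=O)CCc3cccc4c3B(O)OC4)c2)c1`) has not yet been measured. It carries acetyl in place of trifluoromethoxy on an aromatic carbon, meta to a large group: acetyl in place of trifluoromethoxy on an aromatic carbon.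

Among the measured compounds shown here, only one measured step bears on this change, and it concerns the group that leaves. With trifluoromethoxy in place of hydrogen on an aromatic carbon, the measurements show a 1.8-fold higher number from compound 1 to compound 2 (0.26 log units; within the scatter). For the measured compounds named here, no compound with acetyl has been measured, so this single small step is the only guide. No step beyond the scatter is therefore expected in this assay.

The expected change is a 1.3-fold lower number from compound 2 to compound 3 (0.12 log units; within the scatter). For compound 3 the estimated value is 350 nM, with an expected range of 150 nM to 800 nM.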

Compound 3, half-maximal inhibitory concentration: 68 nM
For compound 3 the middle estimate is 5.1-fold (0.71 log units) above the measured one; the whole stated range lies above it.
By their numbers in this assay, from the lowest: compound 3; then compounds 1 and 2 (each within the scatter of the next).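

Acetyl on this aromatic carbon, meta to a large group, shows that the position can carry a substituent with a step beyond the scatter: in this assay, acetyl in place of hydrogen gives a 3.7-fold lower number from compound 1 to compound 3 (0.57 log units; beyond the scatter), whereas the earlier trifluoromethoxy step stayed within the scatter. The exchange of the two groups gives a 6.8-fold lower number from compound 2 to compound 3 (0.83 log units; beyond the scatter), so what sits here matters even though trifluoromethoxy and acetyl each count one hydrogen-bond acceptor and no hydrogen-bond donors, and the counts alone do not separate them. No measurement of any property of either group is at hand to account for this step.

The compounds shown leave open whether the step belongs to acetyl alone or would also appear with a longer chain such as propanoyl, with an acetamido group, or with a carboxylic acid on the same carbon. They also do not tell whether acetyl would give a comparable step on another aromatic carbon of this ring, or with a different group in place of the propanamide chain of the shared core.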